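Pyrrolidine substituent on the aromatic nitrogen of the core

This account rests on a few compounds, and the source may have more. Where it says the series, first, only, none or still open, it means among the compounds named here.

Measured so far:
compound 1, `Nc1ncnc2c1c(-c1cc3ccccc3o1)cn2[C@H]1CCN(C[C@H]2CO2)C1`: 1650 nM
compound 2, `Nc1ncnc2c1c(-c1ccc(Oc3ccccc3)cc1)cn2[C@H]1CCN(C[C@H]2CO2)C1`: > 50000 nM

In a functional assay on Ramos cells (Homo sapiens) for antiproliferative activity (on this read-out lower numbers stand for stronger inhibition and higher numbers for weaker inhibition), compound 1 gives 1650 nM. Compound 2 gives only a limit of the assay, > 50000 nM, and stands at the limit of > 50000 nM in this assay, at which 1 of the 2 values shown sits. Compound 3, `Nc1ncnc2c1c(-c1ccc(Oc3ccccc3)cc1)cn2C[C@H]1CCCN1C(CO)CO`, differs from compound 2 by (1-(2-hydroxy-1-(hydroxymethyl)ethyl)pyrrolidin-2-yl)methyl in place of 1-((oxiran-2-yl)methyl)pyrrolidin-3-yl on an aromatic nitrogen. Among the compounds with values here, no measured step is at hand for this change, so the expected step in this assay is none beyond the usual scatter, with the value likely to stay at the limit. Compound 3 is estimated at 50000 nM, with a range from 20000 nM to 150000 nM. The expected step is a number no higher from compound 2 to compound 3 (the limit leaves the size open).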

Compound 3, half-maximal inhibitory concentration: 15300 nM
Estimate against measurement, compound 3: 3.3-fold (0.51 log units) above, outside the stated range (below it).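

In this assay, (1-(2-hydroxy-1-(hydroxymethyl)ethyl)pyrrolidin-2-yl)methyl in place of 1-((oxiran-2-yl)methyl)pyrrolidin-3-yl on the aromatic nitrogen gives an at least 3.2-fold lower number from compound 2 to compound 3 (0.51 log units; beyond the scatter). This substituent therefore moves the read-out with the rest of the molecule unchanged, and a measurable value here does not need the three-membered ring. The value of compound 2 is a limit, so the full size of the step stays unknown: the limit of > 50000 nM in this assay, at which 1 of the 3 values shown sits.

The change alters ring attachment, the three-membered ring and the hydroxyl groups together, so the part that carries the step stays unassigned. Also open, on these data alone, is how a plain methyl or a carboxylic acid on the pyrrolidine nitrogen would read.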